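This account rests on a few compounds, and the source may have more. Where it says the series, first, only, none or still open, it means among the compounds named here.

Series notes on the shared core. Three compounds have been run in an ADME assay on cells (Hepatocyte, Homo sapiens) for metabolic stability, read by LC-MS, with a stated time of 90 min, tested at 1 uM; on this read-out lower numbers stand for slow clearance and higher numbers for fast clearance. Compound 1 `Cc1nc(N)nc2c1c(-c1ccc3oc(N)nc3c1)nn2C(C)C` carries a methyl on the aromatic carbon in question, and in this assay compound 1 gives < 5 uL/min, a limit of the assay and not a number. Compound 2 `CC(C)n1nc(-c2ccc3oc(N)nc3c2)c2c(Br)nc(N)nc21` carries bromo there, and in this assay compound 2 gives 55 uL/min. Compound 3 `CC(C)n1nc(-c2ccc3oc(N)nc3c2)c2c(C#N)nc(N)nc21` carries cyano, and in this assay compound 3 gives < 5 uL/min, again a limit and not a number. The measured steps are an at least 11-fold higher number from compound 1 to compound 2 (1.04 log units; beyond the scatter), an at least 11-fold lower number from compound 2 to compound 3 (1.04 log units; beyond the scatter) and a step that the two limits leave unreadable from compound 1 to compound 3. Compound 3 therefore stands at the limit of < 5 uL/min in this assay, at which 2 of the 3 values shown sit, with only compound 2 clearly separated from it.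

Compound 4 `CC(C)n1nc(-c2ccc3oc(N)nc3c2)c2c(N)nc(N)nc21` differs from compound 3 in one place: amino in place of cyano on an aromatic carbon. For the measured compounds named here, no measured step exchanges cyano for amino; the step from compound 2 to compound 3 is the nearest point of reference and was large, while the step from compound 1 to compound 3 is unreadable. With two of three values at the limit, compound 4 is expected to remain close to it, so the step of a number no lower from compound 3 to compound 4 (the limit leaves the size open) is expected to be none beyond the scatter. Compound 4 is estimated at 5 uL/min, in the range 2.5 uL/min to 15 uL/min.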

Compound 4, intrinsic clearance in a liver preparation (reported as CLH), per the amount of preparation that the assay uses in the Hepatocyte assay: < 5 uL/min
Compound 4: only a limit was reported; the forecaster's own chance of this, stated with the estimate: 60%; the middle value sits exactly at the limit.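

In the Hepatocyte assay, amino at this position sits with cyano and methyl and apart from bromo, with an at least 11-fold lower number from compound 2 to compound 4 (1.04 log units; beyond the scatter), while the steps among compound 1, compound 3 and compound 4 cannot be read. In a physicochemical assay for solubility, read by HPLC, in phosphate buffer, measured as kinetic solubility, with a stated time of 24 h, at 20 degrees C, at pH 7.4, tested at 100 uM (a lower number here means a less soluble compound, a higher number a more soluble compound), compound 3 gives < 1000 nM, a limit of the assay and not a number. In the physicochemical assay, compound 4 gives 88000 nM, so amino in place of cyano separates two compounds that the clearance read-out leaves together: the measured solubility of compound 3, < 1000 nM, and of compound 4, 88000 nM, an at least 88-fold higher number (1.94 log units; beyond the scatter)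

As far as these compounds go, whether methyl, cyano and amino differ at all in clearance stays open, as all three compounds sit at a limit of the Hepatocyte assay. Also open, from the compounds shown here alone, is where a methoxy or a dimethylamino group on this aromatic carbon would stand in clearance and in solubility.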